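This account rests on a few compounds, and the source may have more. Where it says the series, first, only, none or still open, it means among the compounds named here.

Measured compounds:
- compound 1 `CC(=O)N1CC=C(c2ccn3c(-c4ccc(NC(=O)c5ccc([N+](=O)[O-])o5)cc4)cnc3c2)CC1`: 156 mL.min-1.g-1
- compound 2 `O=C(Nc1ccc(-c2cnc3ccccn23)cc1)c1ccc([N+](=O)[O-])o1`: 85.1 mL.min-1.g-1

In an ADME assay on microsomes from liver (Homo sapiens) for metabolic stability (on this read-out higher numbers stand for fast clearance and lower numbers for slow clearance), compound 1 gives 156 mL.min-1.g-1 and compound 2 gives 85.1 mL.min-1.g-1. Among the compounds with values here, the one measured step, a 1.8-fold lower number from compound 1 to compound 2 (0.26 log units; within the scatter), lies within the scatter, so the two numbers are not distinguished by this read-out; compound 2 stands as the lower of the two, but that ordering carries no weight.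

Compound 3 `Cc1cc(NC(=O)c2ccc([N+](=O)[O-])o2)ccc1-c1cnc2ccccn12` differs from compound 2 by methyl in place of hydrogen on an aromatic carbon. Within the data shown here, no measured step concerns a methyl for hydrogen exchange, so nothing in the data bears directly on this change. Among the measured compounds shown here, the only step available, from compound 1 to compound 2, removed a far larger group and still stayed inside the scatter, which gives no reason to expect the small change to compound 3 to move the number far.

The number for compound 3 in this assay is therefore expected to stay close to that of compound 2, with an estimated step of a 1.1-fold higher number from compound 2 to compound 3 (0.05 log units; within the scatter). The estimate for compound 3 is 95 mL.min-1.g-1, with a range from 45 mL.min-1.g-1 to 200 mL.min-1.g-1.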

Compound 3, intrinsic clearance in microsomes: 51 mL.min-1.g-1
Beside the measured number, compound 3's estimate is 1.9-fold (0.27 log units) above it; the range from low to high includes it.
By their numbers in this assay, from the lowest: compounds 3, 2 and 1 (each within the scatter of the next, the first and the last beyond it).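

Methyl in place of hydrogen on an aromatic carbon, ortho to a group of 9 heavy atoms and meta to a large group, gives a 1.7-fold lower number from compound 2 to compound 3 (0.22 log units; within the scatter) in this assay. This is the only information on this position among the compounds shown, since the step between compound 1 and compound 2 concerned a different place, and it shows that this single added carbon does not produce a difference that the read-out can separate from the usual scatter, so compound 2 and compound 3 count as equivalent in this assay. No supporting measurement bears on this result, so the step stands without any explanation.

Still open, going by these compounds, is whether a larger or different group at the same aromatic carbon, such as ethyl, methoxy, an amine or a carboxylic acid, would give a step beyond the scatter. Also open, on these data alone, is whether methyl at this position would give a similar step on the core of compound 1, which carries the group of 9 heavy atoms, since a single methyl step on one parent says nothing about another.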